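Extending a chain on an imidazole-based series against melanoma cells

This account rests on a few compounds, and the source may have more. Where it says the series, first, only, none or still open, it means among the compounds named here.

Measured compounds:
- compound 1, `C=CCCCCOc1ccccc1-c1cnc(OCCC=C)n1C` — 17000 nM
- compound 2, `C=CCCCCOc1ccccc1-c1cnc(OCCCCC=C)n1C` — 5000 nM
- compound 3, `C=CCCOc1ncc(-c2ccccc2OC)n1C` — 21000 nM

All three were tested in a functional assay on SK-MEL-28 cells (Homo sapiens) for inhibition, read by colorimetric assay and MTT assay, with a stated time of 72 h (a lower number here means a stronger inhibitor, a higher number a weaker inhibitor), so a smaller number points to a more potent compound. Compound 1 gives 17000 nM in this assay, and compound 2 reaches 5000 nM. The two share a core and differ only in one chain: but-3-en-1-yl in place of vinyl on a saturated chain carbon, two bonds along the chain from an oxygen on an aromatic ring. That single change yields a 3.4-fold lower number from compound 1 to compound 2 (0.53 log units; beyond the scatter), a gain that is clearly larger than the usual variation between repeat measurements.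

Compound 3 gives 21000 nM. Its core differs from that of compound 1 in the other chain: hydrogen in place of pent-4-en-1-yl on a saturated chain carbon bound to an oxygen on an aromatic ring. The resulting step, a 1.2-fold higher number from compound 1 to compound 3 (0.09 log units; within the scatter), is small enough that the two values cannot be told apart.

Compound 4, `C=CCCCCOc1ncc(-c2ccccc2OC)n1C`, has not yet been measured. It is related to compound 3 by the same change that links compound 1 to compound 2: but-3-en-1-yl in place of vinyl on a saturated chain carbon, two bonds along the chain from an oxygen on an aromatic ring. Both pairs carry this change at a place described in identical terms, so the step is expected to be of similar size.

For compound 4 in this assay, the expected step is a 3.2-fold lower number from compound 3 to compound 4 (0.51 log units; beyond the scatter), because the same change gave a 3.4-fold lower number from compound 1 to compound 2 (0.53 log units; beyond the scatter). The estimate for compound 4 is therefore 6500 nM, with a likely range from 3000 nM to 15000 nM. This rests on one precedent only, and the different core of compound 3 may shift the outcome.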

Compound 4, half-maximal inhibitory concentration: 13000 nM
Compound 4: the middle estimate sits 2.0-fold (0.30 log units) below what was measured, within the range that was stated.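

In this assay, putting the (hex-5-en-1-yl)oxy chain in place of (but-3-en-1-yl)oxy on the core of compound 3 gives a 1.6-fold lower number from compound 3 to compound 4 (0.21 log units; within the scatter), a step too small to separate from repeat variation, yet it does not stand apart from the earlier step for the same change: the same change on two cores in this assay, a 3.4-fold lower number (0.53 log units; beyond the scatter) from compound 1 to compound 2 and a 1.6-fold lower number (0.21 log units; within the scatter) from compound 3 to compound 4, 2.1-fold (0.32 log units) apart, within the scatter of two such steps

The other change, hydrogen in place of pent-4-en-1-yl, gives a 2.6-fold higher number from compound 2 to compound 4 (0.41 log units; beyond the scatter), and this step likewise does not stand apart from its earlier counterpart, even though only the newer one lies beyond the scatter: the same change on two cores in this assay, a 1.2-fold higher number (0.09 log units; within the scatter) from compound 1 to compound 3 and a 2.6-fold higher number (0.41 log units; beyond the scatter) from compound 2 to compound 4, 2.1-fold (0.32 log units) apart, within the scatter of two such steps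

Together these comparisons show no sign that either change behaves differently on the two cores, but they do not prove that the steps are equal, and they rest on the same four compounds, so they are one small square of data and not two independent tests.

What the compounds shown leave open is how a longer chain, a saturated hexyl chain or a chain ending in an amine would read in this assay. They also leave open whether the terminal double bond of these chains matters at all, since it is present in every chain that was compared here.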